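Removing the tert-butoxycarbonyl group from a dithiocarbamate piperazine

The source may hold more compounds than are shown below. What is called first, only, known or untested is meant among the compounds shown, and "the series" means these compounds.

Measured compounds:
compound 1, `CC(C)(C)OC(=O)N1CCN(C(=S)SCc2cn(-c3ccccc3F)nn2)CC1`, 89600 nM
compound 2, `Cc1ccc(Cn2cc(CSC(=S)N3CCN(C(=O)OC(C)(C)C)CC3)nn2)cc1`, 19700 nM

Among the compounds with values here, in a functional assay on MCF7 cells (Homo sapiens) for inhibition, read by MTT assay, with a stated time of 72 h (on this read-out higher numbers stand for weaker inhibition and lower numbers for stronger inhibition), compound 2 gives the lowest of the two numbers seen so far; the only neighbour is compound 1, and the step of a 4.5-fold lower number from compound 1 to compound 2 (0.66 log units; beyond the scatter) stands beyond the scatter. Compound 3, `Cc1ccc(Cn2cc(CSC(=S)N3CCNCC3)nn2)cc1`, differs from compound 2 in a different place: hydrogen in place of tert-butoxycarbonyl on an amine nitrogen in a ring. Within the data shown here, no measured step concerns this position, since the single step recorded, from compound 1 to compound 2, involves only the group on the aromatic nitrogen, which compound 3 keeps unchanged. The effect of the change on the ring nitrogen in this assay therefore cannot be read from the data at hand. With nothing to point in either direction, compound 3 is expected to give a number close to that of compound 2, 20000 nM, within a wide range from 5000 nM to 80000 nM. The step of a 1.0-fold higher number from compound 2 to compound 3 (0.01 log units; within the scatter) is thus estimated to stay within the scatter.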

Compound 3, half-maximal inhibitory concentration: 53200 nM
The estimate for compound 3 lay 2.7-fold (0.42 log units) below the measured number; low and high end bracket the measured number.
By their numbers in this assay, from the lowest: compound 2; then compounds 3 and 1 (each within the scatter of the next).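

In this assay, replacing tert-butoxycarbonyl with hydrogen on the amine nitrogen in the ring gives a 2.7-fold higher number from compound 2 to compound 3 (0.43 log units; beyond the scatter), a modest change that nonetheless lies beyond the scatter. This shows that the group on this ring nitrogen affects the result, which the earlier step could not show because it changed only the group on the aromatic nitrogen; here, the compound with the free ring nitrogen gives weaker inhibition. No supporting data are available to explain this step.

The compounds shown leave open whether a methyl group, an acetyl group or a longer alkyl chain on this ring nitrogen would match compound 2 or give a lower number. They also leave open whether the same change would give a similar step when the aromatic nitrogen carries the 2-fluorophenyl group of compound 1.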